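Replacing Chloromethyl with Chloropyridinyl on the Amide Carbonyl

A few compounds are considered here, and "the series" means these few. Any claim that something is new, unique, unknown or untested is made for them only; others in the source may bear on it.

Compound 1 `C=CC(=O)Nc1cccc(-c2nc3ccccc3s2)c1`: > 25000 nM; compound 2 `O=C(CCl)Nc1cccc(-c2nc3ccccc3s2)c1`: 8500 nM.

In an ADME assay on BJ cells (Homo sapiens) for inhibition, with a stated time of 72 h (on this read-out higher numbers stand for an effect only at larger amounts of compound and lower numbers for an effect already at smaller amounts), compound 1 reaches only a limit, > 25000 nM. For the measured compounds named here, compound 2 gives 8500 nM, the only full number among the two values. The step of an at least 2.9-fold lower number from compound 1 to compound 2 (0.46 log units; beyond the scatter) is the single measured one, and it touches the same carbonyl carbon, against (the limit of > 25000 nM in this assay, at which 1 of the 2 values shown sits). Compound 3 `O=C(Nc1cccc(-c2nc3ccccc3s2)c1)c1cnccc1Cl` differs by 4-chloropyridin-3-yl in place of chloromethyl on a carbonyl carbon. With the chloromethyl gone, the number is expected to climb, a 2.4-fold higher number from compound 2 to compound 3 (0.37 log units; beyond the scatter), so compound 3 is estimated at 20000 nM, within 6000 nM to 60000 nM.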

Compound 3, half-maximal effective concentration: > 25000 nM
Compound 3: only a limit was reported; the forecaster's own chance of this, stated with the estimate: 50%; at least 1.2-fold (0.09 log units) between middle value and limit.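

In this assay, the carbonyl carbon does not keep the number of compound 2 once 4-chloropyridin-3-yl replaces chloromethyl, giving an at least 2.9-fold higher number from compound 2 to compound 3 (0.46 log units; beyond the scatter). Among the three groups shown at this place, only chloromethyl gives a full number, while vinyl and 4-chloropyridin-3-yl both end at a limit: the limit of > 25000 nM in this assay, at which 2 of the 3 values shown sit. The two limits leave the step between compound 1 and compound 3 unreadable. From the compounds shown here alone, whether bromomethyl or aminomethyl on this carbonyl carbon would give a full number in this assay stays open.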